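Lengthening the alkyl chain of compound 3

The source may report more compounds than this note shows. Statements on the series, on what has been measured and on what is new or still open speak of the compounds shown alone.

Three compounds share one core and differ only in the aryl group on the sulfonyl sulfur: compound 1 `CCCCCCCCCCCCCCNC(=O)[C@@H](NS(=O)(=O)c1ccc(C)cc1)[C@@H](C)O`, compound 2 `CCCCCCCCCCCCCCNC(=O)[C@@H](NS(=O)(=O)c1cccs1)[C@@H](C)O` and compound 3 `CCCCCCCCCCCCCCNC(=O)[C@@H](NS(=O)(=O)c1ccc2ccccc2c1)[C@@H](C)O`. In a functional assay on HepG2 cells (Homo sapiens) for cytotoxicity, read by MTT assay, with a stated time of 48 h (a lower number here means a stronger inhibitor, a higher number a weaker inhibitor), compound 1 gives 10900 nM, compound 2 gives 21600 nM and compound 3 gives 11400 nM. Compound 3 thus holds the second highest number of the three, within the scatter of both others: a 1.0-fold higher number from compound 1 to compound 3 (0.02 log units; within the scatter), a 1.9-fold lower number from compound 2 to compound 3 (0.28 log units; within the scatter), and also a 2.0-fold higher number from compound 1 to compound 2 (0.30 log units; within the scatter). Compound 4 `CCCCCCCCCCCCCCCCCCNC(=O)[C@@H](NS(=O)(=O)c1ccc2ccccc2c1)[C@@H](C)O` keeps the aryl group of compound 3 and alters the chain: butyl in place of hydrogen on a saturated chain carbon, ten or more bonds along the chain from an amide-type nitrogen. Within the data shown here, no measured step touches the chain; all three vary only the aryl group, so they offer no guide to the size or direction of this change. Only a small step, a 1.1-fold lower number from compound 3 to compound 4 (0.06 log units; within the scatter), is expected. The estimate for compound 4 in this assay is 10000 nM, between 3000 nM and 35000 nM.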

Compound 4, half-maximal inhibitory concentration: 19800 nM
Estimate against measurement, compound 4: 2.0-fold (0.30 log units) below, within the range that was stated.
By their numbers in this assay, from the lowest: compounds 1, 3, 4 and 2 (each within the scatter of the next).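

Going from the hydrogen to butyl on a saturated chain carbon gives a 1.7-fold higher number from compound 3 to compound 4 (0.24 log units; within the scatter) in this assay, the first step here that touches the chain rather than the aryl group. With the naphthalen-2-yl group in place, this change therefore shows no clear effect on the number. No supporting measurement bears on this result. Still open, from the compounds shown here alone, is whether a chain shorter than that of compound 3, or one longer than that of compound 4, would move the number beyond the scatter. Also open, going by these compounds, is whether an amine or a carboxylic acid on the chain would do so.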